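Dimethylamino for Methyl on a Sulfonamide Sulfur

The compounds below may be only part of what the source reports. "The series", "measured", "known", "first", "only" and "open" are said of these compounds alone.

Compound 1 `O=C1O[C@@H](CO)CN1c1ccc(-n2cc(-c3ccccn3)cn2)c(F)c1` gives 59 ug/mL in an ADME assay on L02 cells (Homo sapiens) for cytotoxicity, read by MTT assay, with a stated time of 48 h; a lower number here means a stronger inhibitor, a higher number a weaker inhibitor. Compound 2 `COC(=O)CC1CCN(C[C@H]2CN(c3ccc(-n4cc(-c5ccccn5)cn4)c(F)c3)C(=O)O2)CC1` only reaches the limit of this assay, reported as > 400 ug/mL. Compound 3 `CS(=O)(=O)NC[C@H]1CN(c2ccc(-n3cc(-c4ccccn4)cn3)c(F)c2)C(=O)O1` likewise stands at the limit, reported as > 400 ug/mL. Among the compounds with values here, the steps of an at least 6.7-fold higher number from compound 1 to compound 2 (0.83 log units; beyond the scatter) and an at least 6.7-fold higher number from compound 1 to compound 3 (0.83 log units; beyond the scatter) are both beyond the scatter, while a step that the two limits leave unreadable from compound 2 to compound 3 cannot be sized; the only evidence on them is the limit of > 400 ug/mL in this assay, at which 2 of the 3 values shown sit. Compound 4 `CN(C)S(=O)(=O)NC[C@H]1CN(c2ccc(-n3cc(-c4ccccn4)cn3)c(F)c2)C(=O)O1` differs from compound 3 by dimethylamino in place of methyl on a sulfonyl sulfur. Within the data shown here, no measured step touches this position, so the expectation rests on compound 3 alone. Compound 4 is expected to remain at the limit, with a number no higher from compound 3 to compound 4 (the limit leaves the size open) expected to show no change beyond the scatter. The estimate for compound 4 is 400 ug/mL, within 150 ug/mL to 800 ug/mL.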

Compound 4, half-maximal inhibitory concentration: 158 ug/mL
The estimate for compound 4 lay 2.5-fold (0.40 log units) above the measured number, and the stated range covers the measured number.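

In this assay the sulfonyl sulfur proves sensitive: dimethylamino in place of methyl gives an at least 2.5-fold lower number from compound 3 to compound 4 (0.40 log units; beyond the scatter) at this position, the first measured change there. Exchanging the whole side group gives an at least 2.5-fold lower number from compound 2 to compound 4 (0.40 log units; beyond the scatter) in the same direction, while the hydroxy compound still sits lower, with a 2.7-fold higher number from compound 1 to compound 4 (0.43 log units; beyond the scatter) as the remaining gap. The first two steps give only minimum sizes, each starting from a limit: the limit of > 400 ug/mL in this assay, at which 2 of the 4 values shown sit.

On these data alone, whether the added nitrogen or the added carbons matter more remains open. A plain amino group or an ethyl group on the same sulfur would separate the two.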